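Aryl exchange on a cytotoxicity-silent scaffold

This account rests on a few compounds, and the source may have more. Where it says the series, first, only, none or still open, it means among the compounds named here.

Compound 1 `CC(C)CCn1c(Cn2c(=O)n(C3CC3)c3ccncc32)nc2nc(Cl)ccc21`: > 50000 nM
Compound 2 `CC(C)(O)CCCn1c(Cn2c(=O)n(C3CC3)c3ccncc32)nc2nc(Cl)ccc21`: > 50000 nM
Compound 3 `COc1ccc(-n2c(=O)n(Cc3cc4cc(Cl)ccc4n3CCCC#N)c3cnccc32)cc1OC`: > 50000 nM

All three values come from an ADME assay on HeLa cells (Homo sapiens) for cytotoxicity, read by ATP content, with a stated time of 3 days; a lower number here means that less compound is tolerated, a higher number that more compound is tolerated. None of them is a number. Each is a limit of the assay, and the limit of > 50000 nM in this assay, at which 3 of the 3 values shown sit, describes where they sit. Compound 3 therefore stands at that limit, and its value is a limit rather than a measured point. Compounds 1 and 2 stand at the same limit, so no order among the three can be read. For the measured compounds named here, the one step that can be traced between measured compounds, a step that the two limits leave unreadable from compound 1 to compound 2, runs from one limit to another and so cannot be sized in this assay.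

Compound 4 `COc1ccc(-n2c(=O)n(Cc3cc4cc(Cl)ccc4n3CCCC#N)c3cnccc32)c(F)c1` differs from compound 3 in a single place: 2-fluoro-4-methoxyphenyl in place of 3,4-dimethoxyphenyl on an aromatic nitrogen. Going by the values given here, no measured step bears directly on this change, and the only step available has no readable size, so there is nothing in the data that points to a shift in either direction. The shared core and the rest of the molecule are unchanged. On that footing the step of a number no higher from compound 3 to compound 4 (the limit leaves the size open) is expected to be none beyond the scatter, with compound 4 most likely again at the limit. Compound 4 is estimated at 50000 nM, with a range from 20000 nM to 100000 nM.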

Compound 4, half-maximal cytotoxic concentration: > 50000 nM
Compound 4: a limit, no number (the forecaster's own chance of this, stated with the estimate: 85%); the middle value lies on the limit itself.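

In this assay compound 4 gives > 50000 nM, a limit and not a number. For the compounds shown here, compound 3 stands at the same limit, so no step between compound 3 and compound 4 can be read. The compounds shown leave open how much compound each of them tolerates, and whether any structural change would alter that, since all four share one position: the limit of > 50000 nM in this assay, at which 4 of the 4 values shown sit.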